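Two Inactive Analogues and a Hydroxybenzyl Successor

This account rests on a few compounds, and the source may have more. Where it says the series, first, only, none or still open, it means among the compounds named here.

compound 1 `N[C@@H]1CCCN(c2cc(NCc3ccc(Cl)cc3Cl)n3nccc3n2)C1` — in an assay on isolated protein for inhibition of Dipeptidyl peptidase 9 (Homo sapiens) (a higher number here means a weaker inhibitor, a lower number a stronger inhibitor), compound 1 gives > 100000 nM, which is a limit of the assay and not a number.
compound 2 `Cc1ccc(Nc2cc(N3CCC[C@@H](N)C3)nc3ccnn23)c(C)c1` — in this assay compound 2 gives > 100000 nM, likewise only a limit.

Compound 2 therefore stands at the edge of what this assay reports, with no number of its own. Within the data shown here, the one further value shown, for compound 1, is also a limit (the limit of > 100000 nM in this assay, at which 2 of the 2 values shown sit). Among the measured compounds shown here, no step between measured compounds is given, so there is nothing to set a scale for change.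

Compound 3 `N[C@@H]1CCCN(c2cc(NCc3ccc(O)cc3)n3nccc3n2)C1` differs from compound 2 by 4-hydroxybenzyl in place of 2,4-dimethylphenyl on a nitrogen on an aromatic ring. Since compound 1, which also carries a benzyl group on that nitrogen, shows only a limit > 100000 nM, compound 3 is expected to stay at the limit as well, with an expected step from compound 2 of a number no higher from compound 2 to compound 3 (the limit leaves the size open), none beyond the scatter. Compound 3 is estimated at 100000 nM, between 20000 nM and 500000 nM.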

Compound 3, half-maximal inhibitory concentration: > 50000 nM
Compound 3 ended at the assay's limit; the forecaster's own chance of this, stated with the estimate: 70%; the middle value does not contradict the limit.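

Compound 1, compound 2 and compound 3 are all reported only as limits in this assay, so the steps from compound 2 and compound 1 to compound 3 cannot be read. The compounds shown leave open whether any of these three has a measurable inhibitory value in this assay.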